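The compounds below may be only part of what the source reports. "The series", "measured", "known", "first", "only" and "open" are said of these compounds alone.

Compound 1 `O=C(CCc1cccc2c1B(O)OC2)Nc1ccccc1` has the highest of the two plain numbers in an ADME assay on WI-38 cells (Homo sapiens) for cytotoxicity, read by MTT assay, with a stated time of 72 h (on this read-out higher numbers stand for weaker inhibition and lower numbers for stronger inhibition), where compound 1 gives 30000 nM. Compound 2 `O=C(CCc1cccc2c1B(O)OC2)Nc1ccc(F)cc1` gives 12000 nM in this assay. Compound 3 `Cc1ccc(NC(=O)CCc2cccc3c2B(O)OC3)cc1` returns only a limit of the assay in this assay, > 100000 nM, and not a number (the limit of > 100000 nM in this assay, at which 1 of the 3 values shown sits).

Compound 4 `CC(C)(C)OC(=O)Nc1ccc(NC(=O)CCc2cccc3c2B(O)OC3)cc1` differs from compound 1 in one place: (tert-butoxycarbonyl)amino in place of hydrogen on an aromatic carbon.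

For the measured compounds named here, two measured steps touch the same place on the ring. The step of a 2.5-fold lower number from compound 1 to compound 2 (0.40 log units; beyond the scatter) went toward a lower number. The step of an at least 3.3-fold higher number from compound 1 to compound 3 (0.52 log units; beyond the scatter) went toward a higher number, ending at the limit. The two changes at this position therefore pulled in opposite directions, and neither group resembles the (tert-butoxycarbonyl)amino group entering in compound 4, so the direction of the new step is uncertain; a change of at most modest size in either direction seems as likely as none beyond the scatter.

Compound 4 is therefore estimated at 40000 nM, with a range from 12000 nM to 100000 nM, which means an expected step of a 1.3-fold higher number from compound 1 to compound 4 (0.12 log units; within the scatter).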

Compound 4, half-maximal inhibitory concentration: > 100000 nM
Compound 4: only a limit was reported (the forecaster's own chance of this, stated with the estimate: 30%); middle value at least 2.5-fold (0.39 log units) away from the limit.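

In this assay, compound 4 returns only a limit of the assay, > 100000 nM, and not a number. The (tert-butoxycarbonyl)amino group on this aromatic carbon therefore joins methyl on the side of higher numbers, with a step of an at least 3.3-fold higher number from compound 1 to compound 4 (0.52 log units; beyond the scatter), and the contrast with fluoro is an at least 8.3-fold higher number from compound 2 to compound 4 (0.92 log units; beyond the scatter). Of the three groups shown here, only fluoro now goes toward a lower number than hydrogen, and the step between compound 3 and compound 4 cannot be read, since both stand at the limit: the limit of > 100000 nM in this assay, at which 2 of the 4 values shown sit.

As far as these compounds go, how far the true values of compound 3 and compound 4 lie beyond that limit stays open, so methyl and (tert-butoxycarbonyl)amino cannot be ranked against each other. Also open, from the compounds shown here alone, is whether a plain amine or a carboxylic acid at this position would go with fluoro toward a lower number or with the other two toward a higher one.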